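The source may hold more compounds than are shown below. What is called first, only, known or untested is meant among the compounds shown, and "the series" means these compounds.

Compounds measured so far, with their results in a functional assay on HeLa cells (Homo sapiens) for inhibition, read by MTT assay, with a stated time of 48 h; on this read-out lower numbers stand for stronger inhibition and higher numbers for weaker inhibition:

Compound 1 `COc1cc(OC)c(-c2nc3cc(/C=C4\SC(=O)NC4=O)ccc3[nH]2)cc1OC`: 15400 nM
Compound 2 `COc1cc(-c2nc3cc(/C=C4\SC(=O)N(CC(=O)N5CCOCC5)C4=O)ccc3[nH]2)cc(OC)c1OC`: 16300 nM
Compound 3 `COc1ccc(-c2nc3cc(/C=C4\SC(=O)N(CC(=O)N5CCOCC5)C4=O)ccc3[nH]2)cc1OC`: 7510 nM

Among these three, compound 3 gives the lowest number in this assay, and its distance to both others lies beyond the usual scatter: compound 1 sits somewhat higher and compound 2 a little higher still. Among the measured compounds shown here, the only single-point comparison available is the step from compound 2 to compound 3, which reads a 2.2-fold lower number from compound 2 to compound 3 (0.34 log units; beyond the scatter); removing one methoxy group there brought the number down by a modest amount.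

Compound 4 `COc1cc(OC)c(-c2nc3cc(/C=C4\SC(=O)N(CC(=O)N5CCOCC5)C4=O)ccc3[nH]2)cc1OC` has not yet been measured. It arises from compound 3 by the change (methoxy in place of hydrogen on an aromatic carbon). This is the mirror image of the measured step in kind, an added methoxy rather than a removed one, though at a different place on the ring. A modest rise in the number is therefore the most natural expectation, and compound 1, which carries the same trimethoxy pattern on a plainer core, also gives a number above that of compound 3. Compound 4 is expected to show a step of a 1.6-fold higher number from compound 3 to compound 4 (0.20 log units; within the scatter), landing near 12000 nM, plausibly between 5000 nM and 30000 nM.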

Compound 4, half-maximal inhibitory concentration: 510 nM
Estimate against measurement, compound 4: 24-fold (1.37 log units) above; measured number below the stated range.
By their numbers in this assay, from the lowest: compound 4; then compound 3; then compounds 1 and 2 (each within the scatter of the next).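

In this assay, adding one methoxy group to the 3,4-dimethoxyphenyl ring, on the carbon ortho to a large group, gives a 15-fold lower number from compound 3 to compound 4 (1.17 log units; beyond the scatter), so a methoxy group here does something quite unlike the earlier removal of a methoxy group elsewhere on the ring. Placement counts as well as number: 2,4,5-trimethoxyphenyl in place of 3,4,5-trimethoxyphenyl gives a 32-fold lower number from compound 2 to compound 4 (1.50 log units; beyond the scatter). With the 2,4,5-trimethoxyphenyl ring in place, ((morpholin-4-yl)carbonyl)methyl on the amide-type nitrogen gives a 30-fold lower number from compound 1 to compound 4 (1.48 log units; beyond the scatter), while nothing measured here accounts for any of these steps.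

The compounds shown leave open whether a hydroxyl group, a fluorine atom or a longer ethoxy chain at this place would serve as well as methoxy. They also leave open whether a piperazine amide or a carboxylic acid could stand in for the morpholine amide with this ring.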